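This account rests on a few compounds, and the source may have more. Where it says the series, first, only, none or still open, it means among the compounds named here.

Measured in a physicochemical assay for solubility, with a stated time of 4 h, at pH 2.0; on this read-out higher numbers stand for higher solubility and lower numbers for lower solubility:
- compound 1 `Cc1cc(/C=C/C#N)cc(C)c1Oc1cc(Nc2ccc(C#N)cc2)c(N)cc1C(N)=O`: 2.09 ug/mL
- compound 2 `COC(=O)c1cc(N)c(Nc2ccc(C#N)cc2)cc1Oc1c(C)cc(CCC#N)cc1C`: 21.8 ug/mL

Compound 2 stands higher of the two at 21.8 ug/mL, and the gap down to compound 1 lies beyond the scatter. Compound 3 `Cc1cc(CCC#N)cc(C)c1Oc1cc(Nc2ccc(C#N)cc2)c(N)cc1C(N)=O` departs from compound 2 in one place amino in place of methoxy on a carbonyl carbon. Among the compounds with values here, no measured step isolates this change. Within the data shown here, the only guide is compound 1, which also carries carbamoyl and gives 2.09 ug/mL, though it is not a clean comparison. The expected change is a fall beyond the scatter, estimated as a 3.1-fold lower number from compound 2 to compound 3 (0.49 log units; beyond the scatter). For compound 3 the estimated value in this assay is 7 ug/mL, with an expected range of 2 ug/mL to 25 ug/mL.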

Compound 3, solubility: 9.11 ug/mL
The estimate for compound 3 lay 1.3-fold (0.11 log units) below the measured number, and the stated range covers the measured number.
By their numbers in this assay, from the lowest: compound 1; then compound 3; then compound 2.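

In this assay, within the data shown here, the change from methoxycarbonyl to carbamoyl, read alone, gives a 2.4-fold lower number from compound 2 to compound 3 (0.38 log units; beyond the scatter) and is the first clean reading at this carbonyl carbon. With carbamoyl held constant, 2-cyanoethyl in place of 2-cyanoethenyl gives a 4.4-fold higher number from compound 1 to compound 3 (0.64 log units; beyond the scatter) on this aromatic carbon. The gap between compound 1 and compound 2 now splits into two single-place steps, both upward through compound 3. No measurement on hand explains either step.

On these data alone, whether the carbonyl step holds with 2-cyanoethenyl in place remains open. Also open, as far as these compounds go, is what a dimethylamino group or a hydroxyl on that carbonyl carbon would give.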